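The source may report more compounds than this note shows. Statements on the series, on what has been measured and on what is new or still open speak of the compounds shown alone.

Compound 1, with the structure `COc1ccc(C2=NN(C3=NC(=O)/C(=C4\C(=O)Nc5ccccc54)S3)C(c3ccc(OC)cc3)C2)cc1`, is the starting point. In a functional assay on cells (Cancer cell lines, Homo sapiens) for cytotoxicity, read by sulforhodamine B assay, with a stated time of 48 h (on this read-out lower numbers stand for stronger inhibition of growth and higher numbers for weaker inhibition of growth), compound 1 gives 100000 nM. Compound 2, with the structure `COc1ccc(C2=NN(C3=NC(=O)/C(=C4\C(=O)Nc5ccccc54)S3)C(c3ccc(Cl)cc3)C2)cc1`, carries a chloro in place of one methoxy on an aromatic carbon, and in this assay compound 2 gives 100000 nM. Among the measured compounds shown here, the step of no change at the digits printed from compound 1 to compound 2 (within the scatter) shows that this exchange left the read-out where it was, so compound 2 stands level with compound 1, its only measured neighbour, and neither can be called the more potent.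

Compound 3, with the structure `COc1ccc(C2=NN(C3=NC(=O)/C(=C4\C(=O)Nc5ccc(Cl)cc54)S3)C(c3ccc(Cl)cc3)C2)cc1`, differs from compound 2 by chloro in place of hydrogen on an aromatic carbon, sitting on an aromatic carbon of a six-membered aromatic ring of carbon only, part of a fused system of two rings. For the measured compounds named here, the one measured step that bears on this change, the step of no change at the digits printed from compound 1 to compound 2 (within the scatter), was also a chloro entering an aromatic ring and produced no movement beyond the scatter. On that basis the expected step of no change at the digits printed from compound 2 to compound 3 (within the scatter) is none beyond the scatter, and compound 3 is estimated at 100000 nM, within a range from 40000 nM to 200000 nM.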

Compound 3, concentration for total growth inhibition: 460 nM
Estimate against measurement, compound 3: 220-fold (2.34 log units) above, and the stated range ends above it.
By their numbers in this assay, from the lowest: compound 3; then compounds 1 and 2 (each within the scatter of the next).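

In this assay, the step of a 220-fold lower number from compound 2 to compound 3 (2.34 log units; beyond the scatter) shows that this position, an aromatic carbon of the six-membered aromatic ring of carbon only in the fused system of two rings, responds strongly to a single added chloro. The earlier step, no change at the digits printed from compound 1 to compound 2 (within the scatter), also brought a chloro onto an aromatic carbon, but there it replaced a methoxy and the read-out did not move beyond the scatter. Within these three compounds, then, a chloro on an aromatic ring has no single effect: the outcome differs with the place and with the group that leaves, and nothing available here explains the large step at this position.

The compounds shown leave open whether the chloro itself is needed here, since a fluoro, a methyl group, an amine or a carboxylic acid on the same carbon could give a smaller, similar or larger step. They also leave open whether the same chloro would give a step of this size on compound 1, which carries a second methoxy where compound 3 carries its other chloro.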